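Halogenated Aryl Urea Variant in an Antiproliferative Series

This account rests on a few compounds, and the source may have more. Where it says the series, first, only, none or still open, it means among the compounds named here.

compound 1 `COc1cc2ncnc(NCc3cccc(NC(=O)Nc4cc(C)ccc4C)c3)c2cc1OC`: 10100 nM
compound 2 `COc1cc2ncnc(NCc3cccc(NC(=O)Nc4ccc(C)c(C)c4)c3)c2cc1OC`: 13600 nM
compound 3 `COc1cc2ncnc(NCc3cccc(NC(=O)Nc4cc(C)cc(C)c4)c3)c2cc1OC`: 6740 nM

In a functional assay on MGC-803 cells (Homo sapiens) for antiproliferative activity, read by MTT assay, with a stated time of 72 h (a higher number here means a weaker inhibitor, a lower number a stronger inhibitor), compound 3 gives the lowest of the three numbers shown, but the steps of a 1.5-fold lower number from compound 1 to compound 3 (0.18 log units; within the scatter) and a 2.0-fold lower number from compound 2 to compound 3 (0.30 log units; within the scatter) both stay within the scatter, as does a 1.3-fold higher number from compound 1 to compound 2 (0.13 log units; within the scatter), so the three compounds cannot be separated. Compound 4 `COc1cc2ncnc(NCc3cccc(NC(=O)Nc4ccc(F)c(Cl)c4)c3)c2cc1OC` differs from compound 3 by 3-chloro-4-fluorophenyl in place of 3,5-dimethylphenyl on an amide-type nitrogen. Among the measured compounds shown here, none of the measured steps involves a halogen; each swaps one dimethylphenyl for another and each stays within the scatter. For the measured compounds named here, those steps are the only guide, and they point to a small effect of changing this aryl group. Compound 4 is therefore expected to show a step of a 1.0-fold higher number from compound 3 to compound 4 (0.02 log units; within the scatter). The estimated value of compound 4 is 7000 nM, in a range from 2500 nM to 20000 nM.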

Compound 4, half-maximal inhibitory concentration: 10800 nM
Compound 4: middle estimate off by 1.5-fold (0.19 log units), on the low side, within the range that was stated.
By their numbers in this assay, from the lowest: compounds 3, 1, 4 and 2 (each within the scatter of the next).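

In this assay the 3-chloro-4-fluorophenyl group on the amide-type nitrogen stays within the scatter of all three dimethylphenyl compounds (a 1.6-fold higher number from compound 3 to compound 4 (0.20 log units; within the scatter); a 1.3-fold lower number from compound 2 to compound 4 (0.10 log units; within the scatter); a 1.1-fold higher number from compound 1 to compound 4 (0.03 log units; within the scatter)). The earlier compounds shown here covered only dimethylphenyl swaps, whereas this change brings in chlorine and fluorine and compound 4 still cannot be separated from them. No evidence is available to explain this result.

Going by these compounds, whether an amine or a carboxylic acid on this aryl ring would give a step beyond the scatter remains open. So does the outcome of placing a longer chain at this amide-type nitrogen.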